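The source may report more compounds than this note shows. Statements on the series, on what has been measured and on what is new or still open speak of the compounds shown alone.

Compound 1 `COc1ccc(-c2cc3cccc(OC)c3nc2O)cc1`: 10000 nM
Compound 2 `CCN(CC)C(=O)Cn1c(=O)c(-c2ccc(OC)cc2)cc2c(OC)cc(OC)cc21`: 10000 nM

Both values were measured in a functional assay on A 172 cells (Homo sapiens) for cytotoxicity, read by colorimetric assay and MTT assay; on this read-out lower numbers stand for stronger inhibition and higher numbers for weaker inhibition. Compound 2, at 10000 nM, stands level with compound 1, and the two values match at the digits reported, so neither can be ranked above the other. Within the data shown here, no pair of measured compounds differing in a single place is available, which leaves this series without a direct measure of what one change does in this assay.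

The next compound is compound 3 `COc1ccc(-c2cc3c(OC)cc(OC)cc3n(CCC#N)c2=O)cc1`. It keeps the core of compound 2 and carries cyanomethyl in place of diethylcarbamoyl on a saturated chain carbon bound to an aromatic nitrogen. Cut one bond further out, the same difference reads (diethylcarbamoyl)methyl to 2-cyanoethyl.

With only the level values of compound 1 and compound 2 to go on, no shift beyond the scatter is expected in either direction. The estimated step is no change at the digits printed from compound 2 to compound 3 (within the scatter). For compound 3 the expected value is 10000 nM, with an estimated range of 3500 nM to 20000 nM.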

Compound 3, half-maximal inhibitory concentration: 10000 nM
The estimate for compound 3 equals the measured number at the digits printed; the measured number falls inside the stated range.
By their numbers in this assay, from the lowest: compounds 1, 2 and 3 (each within the scatter of the next).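

Among these compounds, compound 2 and compound 3 form the first pair that differs in a single place, and in this assay replacing diethylcarbamoyl with cyanomethyl on a saturated chain carbon bound to an aromatic nitrogen gives no change at the digits printed from compound 2 to compound 3 (within the scatter). At this position, the read-out therefore does not separate a group of 7 heavy atoms with a double bond outside aromatic rings from one of 3 heavy atoms with a triple bond, and each has 1 hydrogen-bond acceptor and no hydrogen-bond donor. No measurement at hand accounts for this result.

Going by these compounds, with these two groups giving the same value at this position, it remains open whether a primary amine, a carboxylic acid or a longer chain there would give a value apart from that of compound 2. The compounds shown also leave open whether a single change elsewhere on the shared core would shift the value in this assay.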